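This account rests on a few compounds, and the source may have more. Where it says the series, first, only, none or still open, it means among the compounds named here.

Measured so far:
compound 1 `ClCc1cccc(Cn2cnc3ncnc(Cl)c32)c1` — 1810 nM
compound 2 `ClCc1cccc(Cn2cnc3c(Cl)ncnc32)c1` — 2230 nM
compound 3 `ClCc1ccc(Cn2cnc3c(Cl)nc(Cl)nc32)cc1` — 2690 nM

In a functional assay on SK-MEL-28 cells (Homo sapiens) for cytotoxicity, read by sulforhodamine B assay, with a stated time of 48 h (on this read-out lower numbers stand for stronger inhibition of growth and higher numbers for weaker inhibition of growth), compound 1 gives the lowest of the three numbers, yet its gaps to compound 2 and to compound 3 lie within the usual scatter, so no order among the three can be read from these values. Compound 4 `ClCc1cccc(Cn2cnc3nc(Cl)nc(Cl)c32)c1` has not been measured. It differs from compound 1 by chloro in place of hydrogen on an aromatic carbon. Among the measured compounds shown here, no comparable step between measured compounds exists; compound 3, which carries two chloro groups on its core, gives a value within the scatter of compound 1 and compound 2, so no step beyond the scatter is expected in this assay. The expected step from compound 1 to compound 4 is a 1.1-fold higher number from compound 1 to compound 4 (0.04 log units; within the scatter). For compound 4 the estimate is 2000 nM, with a range from 900 nM to 4500 nM.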

Compound 4, concentration for 50% growth inhibition: 170 nM
Compound 4: middle estimate off by 12-fold (1.07 log units), on the high side, outside the stated range (below it).
By their numbers in this assay, from the lowest: compound 4; then compounds 1, 2 and 3 (each within the scatter of the next).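

In this assay, among the compounds shown here, chloro in place of hydrogen on the aromatic carbon between two ring nitrogen atoms gives an 11-fold lower number from compound 1 to compound 4 (1.03 log units; beyond the scatter), the only step here beyond the scatter. For the compounds shown here, it shows that growth inhibition in these cells can respond strongly to a change at this position, which the closely grouped values of the earlier compounds did not reveal. No measurement at hand accounts for this step.

From the compounds shown here alone, whether an amine, a methoxy group or a methyl group at this position would give a similar number remains open. So does whether the step depends on the chloro group already on the core of compound 1.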